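The source may hold more compounds than are shown below. What is called first, only, known or untested is meant among the compounds shown, and "the series" means these compounds.

Compound 3 `Cc1nc2c3ccccc3ccc2c2nc3c(ccc4ccccc43)c(C)c12` carries a methyl on the aromatic carbon in question; in a functional assay, read by spectrophotometry, with a stated time of 15 min (a higher number here means a weaker inhibitor, a lower number a stronger inhibitor), compound 3 gives 89.6 ug/mL, the highest of the three numbers shown, though neither of the other two is separated from it beyond the scatter. Compound 1 `Cc1nc2c3ccccc3ccc2c2nc3c(ccc4ccccc43)c(-c3cccnc3)c12` carries pyridin-3-yl at that carbon, and in this assay compound 1 gives 63.6 ug/mL. Compound 2 `Cc1nc2c3ccccc3ccc2c2nc3c(ccc4ccccc43)c(-c3ccccc3S)c12` carries 2-sulfanylphenyl there, and in this assay compound 2 gives 49.6 ug/mL. The two steps onto compound 3 are a 1.4-fold higher number from compound 1 to compound 3 (0.15 log units; within the scatter) and a 1.8-fold higher number from compound 2 to compound 3 (0.26 log units; within the scatter), so the three compounds sit together.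

Compound 4 `Cc1nc2c3ccccc3ccc2c2nc3c(ccc4ccccc43)c(-c3ccccc3)c12` differs from compound 3 in one place: phenyl in place of methyl on an aromatic carbon. Among the measured compounds shown here, the steps that bear on this are the two in which pyridin-3-yl or 2-sulfanylphenyl gave way to methyl at this carbon, a 1.4-fold higher number from compound 1 to compound 3 (0.15 log units; within the scatter) and a 1.8-fold higher number from compound 2 to compound 3 (0.26 log units; within the scatter), both small and both within the scatter. Phenyl in place of methyl is the reverse kind of exchange, and no step beyond the scatter is expected from it; a step of a 1.6-fold lower number from compound 3 to compound 4 (0.21 log units; within the scatter) is the estimate. Compound 4 is expected to give about 55 ug/mL in this assay, with a range from 30 ug/mL to 110 ug/mL.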

Compound 4, half-maximal inhibitory concentration: 84.6 ug/mL
The estimate for compound 4 lay 1.5-fold (0.19 log units) below the measured number; measured number inside the range.
By their numbers in this assay, from the lowest: compounds 2, 1, 4 and 3 (each within the scatter of the next).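

Exchanging methyl for phenyl at the aromatic carbon opposite the ring nitrogen gives a step that stays within the scatter in this assay (a 1.1-fold lower number from compound 3 to compound 4 (0.02 log units; within the scatter)), so an aromatic ring of carbon only at this carbon does not separate from a single methyl. The plain phenyl also separates the two substituted aryl groups from their parent ring: hydrogen in place of sulfanyl on the phenyl ring gives a 1.7-fold higher number from compound 2 to compound 4 (0.23 log units; within the scatter), and phenyl in place of pyridin-3-yl gives a 1.3-fold higher number from compound 1 to compound 4 (0.12 log units; within the scatter), so neither the sulfanyl nor the ring nitrogen of the pyridin-3-yl stands out from the scatter, and methyl, phenyl, pyridin-3-yl and 2-sulfanylphenyl all sit together at this carbon. Nothing beyond these numbers bears on the result, and no reason for this flat picture can be offered.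

Still open, as far as these compounds go, is whether any group at this carbon moves the number beyond the scatter, for example a primary amine, a carboxylic acid, a longer alkyl chain or plain hydrogen. Also open, from the compounds shown here alone, is what happens when the other methyl of the shared core is exchanged, as it stays the same in all four compounds.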